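The source may report more compounds than this note shows. Statements on the series, on what has been measured and on what is new or still open speak of the compounds shown alone.

Measured so far in an ADME assay on MT2 cells (Homo sapiens) for cytotoxicity, read by XTT assay, with a stated time of 4 days; on this read-out lower numbers stand for higher toxicity in this test and higher numbers for lower toxicity in this test:

Compound 1 `Cc1cc(/C=C2\SC(=S)N(c3ccccc3)C2=O)c(C)n1-c1ccc(O)c(C(=O)O)c1`: > 100000 nM, a limit of the assay rather than a number.
Compound 2 `Cc1cc(/C=C2\SC(=S)N(Cc3ccc(Br)cc3)C2=O)c(C)n1-c1ccc(O)c(C(=O)O)c1`: 94400 nM.
Compound 3 `Cc1cc(/C=C2\SC(=S)N(Cc3cccc(Br)c3)C2=O)c(C)n1-c1ccc(O)c(C(=O)O)c1`: 48200 nM.

Compound 3 has the lowest of the two plain numbers, and its nearest neighbour is compound 2, the gap being a 2.0-fold lower number from compound 2 to compound 3 (0.29 log units; within the scatter). The third value is only a limit, for compound 1 (the limit of > 100000 nM in this assay, at which 1 of the 3 values shown sits).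

Compound 4 `COC(=O)c1cccc(CN2C(=O)/C(=C/c3cc(C)n(-c4ccc(O)c(C(=O)O)c4)c3C)SC2=S)c1` is not yet measured. It differs from compound 3 in one place: methoxycarbonyl in place of bromo on an aromatic carbon.

The steps measured so far concern bromine on the benzyl ring, not methoxycarbonyl. Going from compound 1 to compound 3 gave an at least 2.0-fold lower number from compound 1 to compound 3 (0.31 log units; beyond the scatter), and from compound 2 to compound 3 gave a 2.0-fold lower number from compound 2 to compound 3 (0.29 log units; within the scatter); from compound 1 to compound 2 the change was an at least 1.0-fold lower number from compound 1 to compound 2 (0.02 log units; that floor lies within the scatter). None of these speaks to a methoxycarbonyl group, so no step beyond the scatter is expected in this assay in either direction.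

Compound 4 is therefore estimated at 60000 nM, with a range from 25000 nM to 150000 nM, which means an expected step of a 1.2-fold higher number from compound 3 to compound 4 (0.10 log units; within the scatter).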

Compound 4, half-maximal cytotoxic concentration: 38500 nM
Compound 4: middle estimate off by 1.6-fold (0.19 log units), on the high side; the measured number falls inside the stated range.
By their numbers in this assay, from the lowest: compounds 4, 3 and 2 (each within the scatter of the next, the first and the last beyond it). At a limit, above all of these: compound 1.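

In this assay, bromo and methoxycarbonyl at this place on the ring cannot be told apart, even though the entering group is larger and brings 2 hydrogen-bond acceptors: a 1.3-fold lower number from compound 3 to compound 4 (0.10 log units; within the scatter). Among the compounds shown here, the 3-(methoxycarbonyl)benzyl group set against the 4-bromobenzyl group gives a 2.5-fold lower number from compound 2 to compound 4 (0.39 log units; beyond the scatter), a modest step, and the first between two plain numbers to pass the usual scatter. Against the phenyl group on the same nitrogen, the change gives an at least 2.5-fold lower number from compound 1 to compound 4 (0.41 log units; beyond the scatter), which is only a floor, since the starting point is a limit of the assay rather than a number: the limit of > 100000 nM in this assay, at which 1 of the 4 values shown sits.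

With only bromo and methoxycarbonyl shown at this ring carbon, it remains open whether a carboxylic acid, an amine or a simple methyl group there would also stay within the scatter of compound 3. On these data alone, it is also open whether 4-(methoxycarbonyl)benzyl would behave like 3-(methoxycarbonyl)benzyl, and so whether the modest step to compound 4 depends on where the group sits or on the group itself.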